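This account rests on a few compounds, and the source may have more. Where it says the series, first, only, none or still open, it means among the compounds named here.

Measured compounds in a functional assay on MDA-MB-231 cells (Homo sapiens) for antiproliferative activity, read by MTT assay, with a stated time of 72 h; a lower number here means a stronger inhibitor, a higher number a weaker inhibitor:
- compound 1 `O=C(CCc1cccc2c1B(O)OC2)Nc1ccc(Cl)cc1` gives 3600 nM
- compound 2 `O=C(CCc1cccc2c1B(O)OC2)Nc1ccc(Br)cc1` gives 5300 nM
- compound 3 `C#Cc1cccc(NC(=O)CCc2cccc3c2B(O)OC3)c1` gives 1600 nM

Compound 3 has the lowest number of the three, and its gap to compound 1 and to compound 2 lies beyond the scatter in each case. The step from compound 3 to compound 4 `CC(=O)c1cccc(-c2cccc(NC(=O)CCc3cccc4c3B(O)OC4)c2)c1` is 3-acetylphenyl in place of ethynyl on an aromatic carbon. Among the measured compounds shown here, the only measured step, a 1.5-fold higher number from compound 1 to compound 2 (0.17 log units; within the scatter), swaps one halogen for another and lies within the scatter, so it says nothing about a change of this kind. For the measured compounds named here, no measured step bears on it directly, and the expectation therefore rests on compound 3 alone: an estimated step of a 1.1-fold lower number from compound 3 to compound 4 (0.03 log units; within the scatter), with wide uncertainty. Compound 4 is expected to give 1500 nM, with a range from 400 nM to 6000 nM.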

Compound 4, half-maximal inhibitory concentration: 52 nM
Compound 4: the middle estimate sits 29-fold (1.46 log units) above what was measured, and the stated range ends above it.
By their numbers in this assay, from the lowest: compound 4; then compound 3; then compounds 1 and 2 (each within the scatter of the next).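

The aromatic carbon that held ethynyl in compound 3 accepts a much larger group: 3-acetylphenyl adds a second six-membered aromatic ring and a carbonyl, and the number falls sharply (a 31-fold lower number from compound 3 to compound 4 (1.49 log units; beyond the scatter)). Among the compounds shown here, the earlier halogen swap gave no sign that a change at this position could move the number so far. Nothing measured here explains this gain. The compounds shown leave open whether the added ring or its acetyl carries the gain. A plain phenyl, or a phenyl bearing an amine or a carboxylic acid in place of acetyl, would separate the two.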